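A few compounds are considered here, and "the series" means these few. Any claim that something is new, unique, unknown or untested is made for them only; others in the source may bear on it.

Measured so far:
compound 1 `Cc1nc(S(C)(=O)=O)ccc1Oc1ncnc(OC2CCN(C(=O)OC3(C(F)(F)F)COC3)CC2)c1F` — 342 nM
compound 2 `Cc1nc(S(C)(=O)=O)ccc1Oc1ncnc(OC2CCN(C(=S)OC3(C)CC3)CC2)c1F` — 48.8 nM

Both compounds share a core and differ only in the group on the amine nitrogen in a ring. In a functional assay on isolated protein for inhibition of Glucose-dependent insulinotropic receptor (Rattus norvegicus), read by HTRF and cAMP accumulation (a lower number here means that less compound is needed, a higher number that more compound is needed for the effect), compound 1 gives 342 nM, the highest of the two numbers; its nearest neighbour is compound 2, with a 7.0-fold lower number from compound 1 to compound 2 (0.85 log units; beyond the scatter).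

Compound 3 `Cc1nc(S(C)(=O)=O)ccc1Oc1ncnc(OC2CCN(C(=O)c3noc(C(C)(C)F)n3)CC2)c1F` is not yet measured. It differs from compound 1 as follows: a group of 9 heavy atoms (5 carbon, 2 nitrogen, 1 oxygen, 1 fluorine; one five-membered aromatic ring with 3 hetero atoms) in place of a group of 9 heavy atoms (4 carbon, 2 oxygen, 3 fluorine; one four-membered non-aromatic ring with 1 hetero atom), on a carbonyl carbon. Within the data shown here, the replaced group is the (3-(trifluoromethyl)oxetan-3-yl)oxy that compound 1 carries, and the one measured step, from compound 1 to compound 2, also removed that group, though the incoming group there differed from the one entering here; that step was a 7.0-fold lower number from compound 1 to compound 2 (0.85 log units; beyond the scatter). Among the measured compounds shown here, only one step bears on the change and it concerns a different incoming group, so the weight placed on it is limited. A lower number than compound 1 is expected, of a smaller size than the step to compound 2, giving a 2.9-fold lower number from compound 1 to compound 3 (0.45 log units; beyond the scatter) as the estimate. For compound 3 the estimate in this assay is 120 nM, with a range from 35 nM to 420 nM.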

Compound 3, half-maximal effective concentration: 103 nM
Estimate against measurement, compound 3: 1.2-fold (0.07 log units) above; the measured number falls inside the stated range.
By their numbers in this assay, from the lowest: compound 2; then compound 3; then compound 1.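

In this assay, the step to the five-membered aromatic ring with 3 hetero atoms, a 3.3-fold lower number from compound 1 to compound 3 (0.52 log units; beyond the scatter), shows that the number at this position can fall beyond the scatter with a second incoming group, one that keeps the carbonyl carbon and has no three-membered ring or sulfur. That fall does not reach the level of compound 2, as a 2.1-fold higher number from compound 2 to compound 3 (0.32 log units; beyond the scatter) leaves compound 3 beyond the scatter on the higher side, so among these three the group on the amine nitrogen in a ring still separates all the numbers. Nothing available explains why the number moves with these groups.

Compound 3 alone cannot separate the contribution of the aromatic ring from that of the fluorine-bearing carbon substituent it carries, and a methyl or tert-butyl group on that ring, or a simple dimethylamino group on the carbonyl carbon, would bear on this. As far as these compounds go, compound 2 also differs from compound 1 in having a sulfur in place of the carbonyl oxygen, so the share of that atom in its lower number stays open, and a carbonyl counterpart of compound 2 carrying the same 1-methylcyclopropyl group would address it.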